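Adding a methyl to compound 2

This account rests on a few compounds, and the source may have more. Where it says the series, first, only, none or still open, it means among the compounds named here.

In an ADME assay on J774 cells (Mus musculus) for cytotoxicity, read by resazurin assay, with a stated time of 72 h (a higher number here means that more compound is tolerated, a lower number that less compound is tolerated), compound 2 (`C/C(=N\Nc1nc(-c2ccc(Br)cc2)cs1)c1ccc(Cl)c(Cl)c1`) gives > 50000 nM and this is a limit of the assay, not a number. Compound 1 (`C/C(=N\Nc1nc(C)c(C)s1)c1ccc(Cl)c(Cl)c1`) gives a measured value (41800 nM) in this assay and is the only numerical reference in the series. Compound 3 (`C/C(=N\Nc1nc(-c2ccc(Br)cc2)c(C)s1)c1ccc(Cl)c(Cl)c1`) differs from compound 2 by a single change (methyl in place of hydrogen on an aromatic carbon), methyl in place of hydrogen on an aromatic carbon. For the measured compounds named here, no measured step shows this change, so no shift beyond the usual scatter is expected in this assay. The estimated size is an at least 1.1-fold lower number from compound 2 to compound 3 (0.07 log units; that floor lies within the scatter) with no firm direction expected. The estimated value for compound 3 is 42000 nM (range 18000 nM to 80000 nM).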

Compound 3, half-maximal cytotoxic concentration: > 50000 nM
Compound 3 ended at the assay's limit; the forecaster's own chance of this, stated with the estimate: 55%; middle value at least 1.1-fold (0.07 log units) from the limit.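

In this assay compound 3 gives > 50000 nM, a limit of the assay and not a number. Methyl on the aromatic carbon next to the ring sulfur leaves compound 3 at the same limit as compound 2, and that step cannot be read: the limit of > 50000 nM in this assay, at which 2 of the 3 values shown sit. With 4-bromophenyl in place of methyl on an aromatic carbon, the comparison gives an at least 1.1-fold higher number from compound 1 to compound 3 (0.07 log units; that floor lies within the scatter).

Still open, on these data alone, is whether an amine or a carboxylic acid on this aromatic carbon would give a number rather than a limit in this assay.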